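Aryl ring methylation on the imide nitrogen: compound 4

This account rests on a few compounds, and the source may have more. Where it says the series, first, only, none or still open, it means among the compounds named here.

Compound 3 `Cc1cccc(N2C(=O)[C@H]3[C@H](ON4[C@@H]3C(=O)N(C)[C@@]43C[C@H](C)CC[C@H]3C(C)C)C2=O)c1` stands second of the three measured numbers in a functional assay, read by spectrophotometry, with a stated time of 2 h, tested at 1 mg/mL (on this read-out higher numbers stand for a stronger effect at the one concentration tested and lower numbers for a weaker effect), where compound 3 gives 39%. In this assay compound 1 `CC(C)[C@@H]1CC[C@@H](C)C[C@@]12N(C)C(=O)[C@@H]1[C@H]3C(=O)N(c4ccccc4)C(=O)[C@H]3ON12` gives 35.4% and compound 2 `CC(C)[C@@H]1CC[C@@H](C)C[C@@]12N(C)C(=O)[C@@H]1[C@H]3C(=O)N(c4ccc(Cl)cc4)C(=O)[C@H]3ON12` gives 53.7%. The steps to compound 3 are a number 3.6 percentage points higher from compound 1 to compound 3 (within the scatter) and a number 14.7 percentage points lower from compound 2 to compound 3 (beyond the scatter), while a number 18.3 percentage points higher from compound 1 to compound 2 (beyond the scatter) is the only clear gain among the three. Compound 4 `Cc1ccc(N2C(=O)[C@H]3[C@H](ON4[C@@H]3C(=O)N(C)[C@@]43C[C@H](C)CC[C@H]3C(C)C)C2=O)c(C)c1` differs from compound 3 by 2,4-dimethylphenyl in place of 3-methylphenyl on an amide-type nitrogen in a ring. Going by the values given here, no measured step adds a second methyl to this ring; the single methyl addition, a number 3.6 percentage points higher from compound 1 to compound 3 (within the scatter), lay within the scatter, and the clear gain came from chloro. Compound 4 is therefore expected to move by a number 1 percentage points higher from compound 3 to compound 4 (within the scatter), a step within the scatter. The estimate for compound 4 is 40%, in the range 25% to 55%.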

Compound 4, a percentage reported as activity, at one concentration (the size of the read-out at that concentration, not a potency): 53.1%
The estimate for compound 4 lay 13.1 percentage points below the measured number, and the stated range covers the measured number.
By their numbers in this assay, from the lowest: compounds 1 and 3 (each within the scatter of the next); then compounds 4 and 2 (each within the scatter of the next).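

Going by these compounds alone, on the amide-type nitrogen in a ring, this assay shows that chloro is not the only change giving a clear gain, with 2,4-dimethylphenyl giving a number 14.1 percentage points higher from compound 3 to compound 4 (beyond the scatter) and a number 17.7 percentage points higher from compound 1 to compound 4 (beyond the scatter). Against 4-chlorophenyl, the change gives a number 0.6 percentage points lower from compound 2 to compound 4 (within the scatter), so these two aryl groups cannot be separated here. No evidence available here accounts for the gain.

The step from 3-methylphenyl alters both the number and placement of methyl groups, leaving their separate contributions unresolved. Also open, on these data alone, is how 2,4-dichlorophenyl or 4-methoxyphenyl would read at this nitrogen.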